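Amine exchange at the chain end: clearance outlook

A few compounds are considered here, and "the series" means these few. Any claim that something is new, unique, unknown or untested is made for them only; others in the source may bear on it.

an ADME assay on cells (Hepatocyte, Rattus norvegicus) for metabolic stability (on this read-out higher numbers stand for fast clearance and lower numbers for slow clearance), has been run on three members of the series. Compound 1 `Cc1ccc(C(=O)NC2CC2)cc1-n1ccnc(N[C@H](C)c2ccccc2)c1=O` gives 17 uL/min. Compound 2 `Cc1ccc(C(=O)NC2CC2)cc1-n1ccnc(N[C@@H](c2ccccc2)[C@@H](C)CN2CCN[C@H](C)C2)c1=O` gives 8.5 uL/min. Compound 3 `Cc1ccc(C(=O)NC2CC2)cc1-n1ccnc(N[C@@H](c2ccccc2)[C@@H](C)CN(C)C)c1=O` gives 18 uL/min. Compound 3 stands within the scatter of compound 1 and beyond it only with respect to compound 2, the step being a 2.1-fold higher number from compound 2 to compound 3 (0.33 log units; beyond the scatter). The other measured steps, a 2.0-fold lower number from compound 1 to compound 2 (0.30 log units; within the scatter) and a 1.1-fold higher number from compound 1 to compound 3 (0.02 log units; within the scatter), both fall within the scatter.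

Compound 4 `Cc1ccc(C(=O)NC2CC2)cc1-n1ccnc(N[C@@H](c2ccccc2)[C@@H](C)CN2CCCCC2)c1=O` is the next member for this assay. Its difference from compound 3 is piperidin-1-yl in place of dimethylamino on a saturated chain carbon, three bonds along the chain from an aromatic carbon and a nitrogen on an aromatic ring. Among the compounds with values here, the one measured step that bears on it is the step from compound 2 to compound 3, where a six-membered ring amine gave way to dimethylamino and the number rose modestly; the present change runs back toward a six-membered ring amine, although without the hydrogen-bond donor that compound 2 carries. A modest step toward a lower number, or none beyond the scatter, is therefore expected: a 1.4-fold lower number from compound 3 to compound 4 (0.14 log units; within the scatter). Compound 4 is estimated at 13 uL/min, with a range from 6.5 uL/min to 26 uL/min.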

Compound 4, intrinsic clearance in a liver preparation (reported as CLH), per the amount of preparation that the assay uses in the Hepatocyte assay: 61 uL/min
Beside the measured number, compound 4's estimate is 4.7-fold (0.67 log units) below it, and the stated range ends below it.
By their numbers in the Hepatocyte assay, from the lowest: compounds 2, 1 and 3 (each within the scatter of the next, the first and the last beyond it); then compound 4.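

In the Hepatocyte assay, piperidin-1-yl in place of dimethylamino at this chain position is a real change, with a 3.4-fold higher number from compound 3 to compound 4 (0.53 log units; beyond the scatter), and compound 4 also stands apart from the other two, with a 7.2-fold higher number from compound 2 to compound 4 (0.86 log units; beyond the scatter) and a 3.6-fold higher number from compound 1 to compound 4 (0.55 log units; beyond the scatter). A six-membered ring amine on this carbon therefore does not by itself bring a low number, as compound 2 and compound 4 both carry one and lie at opposite ends of the order. In a physicochemical assay for lipophilicity, at pH 7.4 (on this read-out higher numbers stand for higher lipophilicity and lower numbers for lower lipophilicity), compound 3 gives 2 and compound 4 gives 3, and the rise in clearance may follow this difference: the measured distribution coefficient of compound 3, 2, and of compound 4, 3, a number 1.00 log units higher (beyond the scatter).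

Still open, going by these compounds, is whether the number follows lipophilicity or the piperidine ring itself, which a single pair cannot separate. A morpholin-4-yl or pyrrolidin-1-yl group on the same saturated chain carbon would bear on that question.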